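The source may hold more compounds than are shown below. What is called first, only, known or untested is meant among the compounds shown, and "the series" means these compounds.

Measured compounds:
Compound 1 `CCCOCC(=O)Nc1cc2nc(C3CCCCC3)[nH]c2cc1N(CC)CC` in an ADME assay on Vero cells (Chlorocebus sabaeus) for cytotoxicity, read by resazurin assay, with a stated time of 3 days (on this read-out lower numbers stand for stronger inhibition and higher numbers for weaker inhibition), gives > 100 ug/mL, a limit of the assay.
Compound 2 `CCCOCC(=O)Nc1cc2nc(C3CCCCC3)[nH]c2cc1N(C)C` in this assay gives < 50 ug/mL, a limit of the assay.
Compound 3 `CN(C)c1cc2[nH]c(C3CCCCC3)nc2cc1NC(=O)c1cccc(Br)c1` in this assay gives > 100 ug/mL, a limit of the assay.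

The cores of compound 2 and compound 3 differ by 3-bromophenyl in place of propoxymethyl on a carbonyl carbon; the step is an at least 2.0-fold higher number from compound 2 to compound 3 (0.30 log units; that floor lies within the scatter). Compound 1 differs from compound 2 by diethylamino in place of dimethylamino on an aromatic carbon, which gave an at least 2.0-fold higher number from compound 2 to compound 1 (0.30 log units; that floor lies within the scatter).

Compound 4 `CCN(CC)c1cc2[nH]c(C3CCCCC3)nc2cc1NC(=O)c1cccc(Br)c1` is not yet measured. It differs from compound 3 by diethylamino in place of dimethylamino on an aromatic carbon. The surroundings differ in words: in compound 2 the place is ortho to a ((propoxymethyl)carbonyl)amino group (8 heavy atoms), in compound 3 ortho to a large group, so this is the same kind of change, not the same.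

A step that the limit leaves unreadable from compound 3 to compound 4 is expected for compound 4 beside an at least 2.0-fold higher number from compound 2 to compound 1 (0.30 log units; that floor lies within the scatter), resting on compound 3 sitting at the limit of > 100 ug/mL in this assay, at which 2 of the 3 values shown sit, already. Compound 4 is estimated at 150 ug/mL, from 80 ug/mL to 400 ug/mL, most likely again a limit.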

Compound 4, half-maximal inhibitory concentration: > 100 ug/mL
Compound 4 was reported as a limit; the forecaster's own chance of this, stated with the estimate: 85%; the middle value lies beyond the limit too.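

In this assay compound 4 gives > 100 ug/mL, a limit of the assay; compound 1 and compound 3 also stand at limits, so neither step into compound 4 can be read. Going by these compounds, how far these three compounds lie beyond that limit stays open.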